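The compounds below may be only part of what the source reports. "The series", "measured", "known", "first", "only" and "open" are said of these compounds alone.

Three ureas sharing one core have been measured in an assay on microsomes for inhibition of acyl-CoA:cholesterol acyltransferase (Oryctolagus cuniculus); on this read-out lower numbers stand for stronger inhibition and higher numbers for weaker inhibition. Compound 1 `Cc1ccccc1C1(CNC(=O)Nc2c(C(C)C)cccc2C(C)C)CCCC1` gives 17 nM; compound 2 `CC(C)c1ccc(C2(CNC(=O)Nc3c(C(C)C)cccc3C(C)C)CCCC2)cc1` gives 48 nM; compound 3 `CC(C)c1cccc(C(C)C)c1NC(=O)NCC1(c2ccc(F)cc2)CCCC1` gives 23 nM. On these numbers compound 1 stands lowest of the three: its nearest neighbour is compound 3, with a step of a 1.4-fold higher number from compound 1 to compound 3 (0.13 log units; within the scatter) that lies within the scatter, and its furthest is compound 2, with a 2.8-fold higher number from compound 1 to compound 2 (0.45 log units; beyond the scatter), a step beyond the scatter. Between the other two, a 2.1-fold lower number from compound 2 to compound 3 (0.32 log units; beyond the scatter) is also beyond the scatter.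

Compound 4 `CC(C)c1cccc(C(C)C)c1NC(=O)NCC1(c2cccc([N+](=O)[O-])c2)CCCC1` has not yet been measured. It differs from compound 1 in one place: 3-nitrophenyl in place of 2-methylphenyl on a saturated ring carbon. The measured steps that bear on this are the two that also replace the 2-methylphenyl on the saturated ring carbon: a 2.8-fold higher number from compound 1 to compound 2 (0.45 log units; beyond the scatter), a modest rise, and a 1.4-fold higher number from compound 1 to compound 3 (0.13 log units; within the scatter), which stays within the scatter. Within the data shown here, none of the measured compounds carries a nitro group, so the data give no direct guide to this particular group. The expectation for compound 4 is therefore a small rise in this assay, of about a 2.1-fold higher number from compound 1 to compound 4 (0.31 log units; beyond the scatter), which may or may not clear the scatter. Compound 4 is estimated to give 35 nM, with a range from 12 nM to 100 nM.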

Compound 4, half-maximal inhibitory concentration: 51 nM
For compound 4 the middle estimate is 1.5-fold (0.16 log units) below the measured one; the measured number falls inside the stated range.
By their numbers in this assay, from the lowest: compounds 1 and 3 (each within the scatter of the next); then compounds 2 and 4 (each within the scatter of the next).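

Placing 3-nitrophenyl on the saturated ring carbon gives a 3.0-fold higher number from compound 1 to compound 4 (0.48 log units; beyond the scatter) in this assay, so a nitro-bearing phenyl is accommodated here, but not with the number of compound 1. The step of a 2.2-fold higher number from compound 3 to compound 4 (0.35 log units; beyond the scatter) is also beyond the scatter, which separates the 3-nitrophenyl from the 4-fluorophenyl and sets compound 4 apart from the pair formed by compounds 1 and 3. By contrast, a 1.1-fold higher number from compound 2 to compound 4 (0.03 log units; within the scatter) lies within the scatter, so two quite different groups, 3-nitrophenyl and 4-isopropylphenyl, cannot be told apart on this read-out, and the set now falls into two tiers, with compounds 1 and 3 in one and compounds 2 and 4 in the other.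

Nothing available accounts for why these phenyl groups sort into these tiers. The compounds shown also leave open whether the place of a group on the phenyl ring or the group itself sets the number, and how an amine or a carboxylic acid in place of the nitro group, or a 4-nitrophenyl in place of the 3-nitrophenyl, would read in this assay.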